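Phenyl substituent removal in a KAT2B binder series

The source may report more compounds than this note shows. Statements on the series, on what has been measured and on what is new or still open speak of the compounds shown alone.

Measured so far:
compound 1, `CN1C[C@H](Nc2nc3cc[nH]c3c(=O)n2C)C[C@H](c2cccc(Br)c2)C1`: 22 nM
compound 2, `CCCCc1ccc([C@H]2C[C@@H](Nc3nc4cc[nH]c4c(=O)n3C)CN(C)C2)cc1`: 35 nM

In an assay for binding affinity to histone acetyltransferase KAT2B (Homo sapiens), read by HTRF, with a stated time of 15 h (on this read-out higher numbers stand for weaker inhibition and lower numbers for stronger inhibition), compound 1 gives 22 nM and compound 2 gives 35 nM. Compound 2 carries the higher of the two numbers, but its gap to compound 1 lies within the scatter, so the two read as comparable and neither is called the stronger binder. For the measured compounds named here, no pair among the measured compounds differs in only one place, so no step of known size is available.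

Compound 3, `CN1C[C@H](Nc2nc3cc[nH]c3c(=O)n2C)C[C@H](c2ccccc2)C1`, is not yet measured. Relative to compound 2 the change is hydrogen in place of butyl on an aromatic carbon of a six-membered aromatic ring of carbon only. Going by the values given here, with no measured step to lean on, the expectation is a modest change in this assay, in the weaker direction, as a 1.3-fold higher number from compound 2 to compound 3 (0.11 log units; within the scatter), but not clearly beyond the scatter. Compound 3 is estimated at 45 nM, with a range from 12 nM to 160 nM.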

Compound 3, half-maximal inhibitory concentration: 41 nM
For compound 3 the middle estimate is 1.1-fold (0.04 log units) above the measured one; the range from low to high includes it.
By their numbers in this assay, from the lowest: compounds 1, 2 and 3 (each within the scatter of the next).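

In this assay hydrogen in place of butyl on an aromatic carbon gives a 1.2-fold higher number from compound 2 to compound 3 (0.07 log units; within the scatter) and loss of the bromo group gives a 1.9-fold higher number from compound 1 to compound 3 (0.27 log units; within the scatter) as the second step. Both steps stay within the scatter, so compound 3, with neither substituent, reads as comparable to compound 1 and to compound 2, and neither butyl nor bromo is shown to matter for the number in this assay. No measurement on hand accounts for the size of these steps.

Still open, on these data alone, is whether an amine, a carboxylic acid or a longer chain on this six-membered aromatic ring would give a step beyond the scatter. Also open, as far as these compounds go, is whether the flat result for butyl and bromo holds at other places on the ring.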